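The source may report more compounds than this note shows. Statements on the series, on what has been measured and on what is new or still open speak of the compounds shown alone.

Series in an assay on isolated protein for inhibition of coagulation factor X (Oryctolagus cuniculus), tested at 1 uM; on this read-out lower numbers stand for less inhibition and higher numbers for more inhibition at the one concentration tested (going by the name of the read-out):
compound 1 `Cc1c(S(=O)(=O)N[C@H]2CCN(Cc3cc4[nH]cccc-4n3)C2=O)sc2ccc(Cl)cc12` gives 40%
compound 2 `O=C1[C@@H](NS(=O)(=O)c2ccc(-c3ccncc3)s2)CCN1Cc1cc2c[nH]ccc-2n1` gives 21%
compound 3 `Cc1c(S(=O)(=O)N[C@H]2CCN(Cc3cc4c[nH]ccc-4n3)C2=O)sc2ccc(Cl)cc12` gives 37%

Compound 3 sits second highest of the three numbers; its nearest neighbour is compound 1, and the two values lie within the scatter of each other, while compound 2 sits beyond the scatter on the low side. Compound 4 `Cc1c(S(=O)(=O)N[C@H]2CCN(Cc3cc4cc[nH]cc-4n3)C2=O)sc2ccc(Cl)cc12` has the same atoms as compound 3, joined differently: a group of 9 heavy atoms (7 carbon, 2 nitrogen; one five-membered aromatic ring with 1 hetero atom, one six-membered aromatic ring with 1 hetero atom) in place of a group of 9 heavy atoms (7 carbon, 2 nitrogen; one five-membered aromatic ring with 1 hetero atom, one six-membered aromatic ring with 1 hetero atom), on a saturated chain carbon bound to an amide-type nitrogen in a ring. Within the data shown here, the one measured step of this kind is a number 3 percentage points lower from compound 1 to compound 3 (within the scatter), a move within the scatter. Among the measured compounds shown here, only that step bears on the change; no other pair alters the group on the saturated chain carbon bound to the amide-type nitrogen in the ring. Compound 4 is therefore expected to show no change at the digits printed from compound 3 to compound 4 (within the scatter), a step no larger than the scatter. The estimate for compound 4 is 37%, with a range from 25% to 48%.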

Compound 4, a percentage reported as inhibition, at one concentration (the size of the read-out at that concentration, not a potency): 52%
Beside the measured number, compound 4's estimate is 15 percentage points below it; the measured number lies above the stated range.
By their numbers in this assay, from the lowest: compound 2; then compounds 3 and 1 (each within the scatter of the next); then compound 4.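

In this assay the group on the saturated chain carbon bound to an amide-type nitrogen in a ring proves sensitive to how its atoms are joined: the number moves by a number 15 percentage points higher from compound 3 to compound 4 (beyond the scatter) and by a number 12 percentage points higher from compound 1 to compound 4 (beyond the scatter) even though the groups match in heavy atoms and in hydrogen-bond donors and acceptors. The earlier step between the same kind of groups stayed within the scatter. No measurement here bears on the reason for this difference.

On these data alone, it remains open whether the group entering in compound 4 gives a similar step with the sulfonamide part of compound 2. As far as these compounds go, the effect of an amine added to that group also remains open.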